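Quinoline-oxadiazole piperidine ureas: Shh Light II notes

This account rests on a few compounds, and the source may have more. Where it says the series, first, only, none or still open, it means among the compounds named here.

Measured compounds:
- compound 1, `O=C(Nc1ccccc1Cl)N1CCC(c2nc(-c3ccc4ccccc4n3)no2)CC1` — 510 nM
- compound 2, `Cn1c(-c2noc(C3CCN(C(=O)NC4CCS(=O)(=O)CC4)CC3)n2)nc2ccccc21` — 350 nM

In a functional assay on Shh Light II cells (Mus musculus) for inhibition, read by a luciferase reporter (on this read-out lower numbers stand for stronger inhibition and higher numbers for weaker inhibition), compound 1 gives 510 nM and compound 2 gives 350 nM. Compound 1 holds the higher of the two numbers, but the gap to compound 2 lies within the scatter, so the two cannot be ordered on this read-out. Going by the values given here, no pair of measured compounds differs in a single place, so no measured step is available to calibrate the change now under consideration.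

Compound 3, `O=C(N1CCC(c2nc(-c3ccc4ccccc4n3)no2)CC1)N1CCCc2ccccc21`, is not yet measured in this assay. It differs from compound 1 in one place: 1,2,3,4-tetrahydroquinolin-1-yl in place of (2-chlorophenyl)amino on a carbonyl carbon. Among the compounds with values here, with no comparable measured step, the size and direction of the effect are unknown; the working assumption is a step not clearly beyond the scatter, with a wide range allowed either way. Compound 3 is therefore expected to come in at about 700 nM, between 150 nM and 3000 nM, which corresponds to an estimated step of a 1.4-fold higher number from compound 1 to compound 3 (0.14 log units; within the scatter).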

Compound 3, half-maximal inhibitory concentration: 2300 nM
Compound 3: the middle estimate sits 3.3-fold (0.52 log units) below what was measured, within the range that was stated.
By their numbers in this assay, from the lowest: compounds 2 and 1 (each within the scatter of the next); then compound 3.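

In this assay, 1,2,3,4-tetrahydroquinolin-1-yl in place of (2-chlorophenyl)amino on a carbonyl carbon gives a 4.5-fold higher number from compound 1 to compound 3 (0.65 log units; beyond the scatter) with weaker inhibition, a step beyond the scatter and the only one in the series that can be read. This place on the carbonyl carbon is therefore not indifferent to the group it carries: with the rest of compound 1 unchanged, this one exchange moves the number. The exchange also changes several things at once, since the hydrogen-bond donor of the leaving group is gone, a non-aromatic ring with a hetero atom enters and the chlorine leaves. No measurement bears on the origin of the step.

Which of these differences carries the step stays open. A (2-chlorophenyl)(methyl)amino group or a plain phenylamino group on the same carbonyl carbon would separate the amide hydrogen, the closed ring and the chlorine from one another.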